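Sulfonyl aryl variation in the EP3 antagonist series

A few compounds are considered here, and "the series" means these few. Any claim that something is new, unique, unknown or untested is made for them only; others in the source may bear on it.

Compound 3 `O=C(NC/C=C1\CCCc2cnn(Cc3ccc(Cl)cc3Cl)c21)NS(=O)(=O)c1cccs1` gives 28 nM in a functional assay on CHO-K1 cells for antagonist activity at prostaglandin E2 receptor EP3 subtype (Homo sapiens), read by TR-FRET and cAMP accumulation, with a stated time of 30 min (a higher number here means a weaker inhibitor, a lower number a stronger inhibitor), the second highest of the three numbers recorded. Its nearest neighbour is compound 2 `COc1ccc(S(=O)(=O)NC(=O)NC/C=C2\CCCc3cnn(Cc4ccc(Cl)cc4Cl)c32)cc1` at 29 nM, a gap within the scatter; its furthest is compound 1 `COc1ccc(Cl)cc1S(=O)(=O)NC(=O)NC/C=C1\CCCc2cnn(Cc3ccc(Cl)cc3Cl)c21` at 8 nM, a gap beyond the scatter.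

The next compound, compound 4 `COc1ccccc1S(=O)(=O)NC(=O)NC/C=C1\CCCc2cnn(Cc3ccc(Cl)cc3Cl)c21`, differs from compound 3 as follows: 2-methoxyphenyl in place of thiophen-2-yl on a sulfonyl sulfur.

Among the compounds with values here, three measured steps bear on this change. The step of a 3.5-fold higher number from compound 1 to compound 3 (0.54 log units; beyond the scatter) and the step of a 3.6-fold higher number from compound 1 to compound 2 (0.56 log units; beyond the scatter) both show that replacing 5-chloro-2-methoxyphenyl on the sulfonyl sulfur raises the number by a modest but real margin, whether the replacement is thiophen-2-yl or 4-methoxyphenyl. The step of a 1.0-fold lower number from compound 2 to compound 3 (0.02 log units; within the scatter) shows that these two replacements are indistinguishable within the scatter. Within the data shown here, the entering 2-methoxyphenyl of compound 4 differs from the 5-chloro-2-methoxyphenyl of compound 1 only by the missing chloro group, and no measured pair isolates that group. A lower number than compound 3 is therefore expected, but smaller than the full step back to compound 1: the estimated step is a 1.9-fold lower number from compound 3 to compound 4 (0.27 log units; within the scatter). For compound 4 the expected value in this assay is 15 nM, within a range of 5 nM to 45 nM.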

Compound 4, half-maximal inhibitory concentration: 114 nM
For compound 4 the middle estimate is 7.6-fold (0.88 log units) below the measured one; the whole stated range lies below it.
By their numbers in this assay, from the lowest: compound 1; then compounds 3 and 2 (each within the scatter of the next); then compound 4.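

The chloro group on the sulfonyl aryl ring can now be read on its own: in this assay, hydrogen in place of chloro on an aromatic carbon gives a 14-fold higher number from compound 1 to compound 4 (1.15 log units; beyond the scatter), a large step, whereas the earlier changes on the sulfonyl sulfur were all modest or within the scatter. The 2-methoxyphenyl group alone does not carry the low number of compound 1, since the step of a 4.1-fold higher number from compound 3 to compound 4 (0.61 log units; beyond the scatter) and the step of a 3.9-fold higher number from compound 2 to compound 4 (0.59 log units; beyond the scatter) both run upward, beyond the scatter. The standing of the 2-methoxyphenyl compounds therefore turns on the chloro group: with it, compound 1 has the lowest number of the four, and without it, compound 4 has the highest.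

No measurement shown gives a reason for the size of these steps.

Still open, on these data alone, is whether bromo, fluoro or methyl in place of that chloro group would keep the low number of compound 1. Also open, as far as these compounds go, is whether chloro added to the thiophen-2-yl of compound 3 or to the 4-methoxyphenyl of compound 2 would lower the number by a step of similar size.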